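Cytotoxicity of Four Nitroimidazooxazines on Vero Cells

A few compounds are considered here, and "the series" means these few. Any claim that something is new, unique, unknown or untested is made for them only; others in the source may bear on it.

This account concerns four compounds that share a nitroimidazooxazine core and differ in the aromatic group attached to it. Compound 1 has the structure `O=[N+]([O-])c1cn2c(n1)OC[C@@H](OCc1cccc(-c3ccc(F)cc3)c1)C2` and compound 2 the structure `COc1ccc(-c2cccc(CO[C@@H]3COc4nc([N+](=O)[O-])cn4C3)c2)cc1F`; compound 3 is `O=[N+]([O-])c1cn2c(n1)OC[C@@H](OCc1ccc(-c3ccc(F)cc3)s1)C2` and compound 4, not yet measured, is `COc1ccc(-c2ccc(CO[C@@H]3COc4nc([N+](=O)[O-])cn4C3)s2)cc1F`. The difference between the core of compound 1 and the core of compound 3 is not broken down here.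

The compounds were examined in an ADME assay on Vero cells (Chlorocebus sabaeus) for cytotoxicity, with a stated time of 72 h; a higher number here means a weaker inhibitor, a lower number a stronger inhibitor. In this assay compound 1 reaches only a limit, > 128000 nM. Compound 2 likewise gives only a limit in this assay, > 128000 nM. Compound 3 also stands at a limit in this assay, > 128000 nM. All three values therefore sit at the same point, as summarised by the limit of > 128000 nM in this assay, at which 3 of the 3 values shown sit, and the step that the two limits leave unreadable from compound 1 to compound 2 cannot be read from them.

The change from compound 1 to compound 2 is 3-fluoro-4-methoxyphenyl in place of 4-fluorophenyl on an aromatic carbon. The change from compound 3 to compound 4 is 3-fluoro-4-methoxyphenyl in place of 4-fluorophenyl on an aromatic carbon. The two are the same kind of change, but not the same: in compound 1 the exchanged group sits on a six-membered aromatic ring of carbon only, meta to a large group, whereas in compound 3 it sits on a five-membered aromatic ring with one sulfur, next to the ring sulfur.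

Because compound 3 already shows only the limit > 128000 nM, compound 4 is expected to give a step of a number no higher from compound 3 to compound 4 (the limit leaves the size open) in this assay, meaning essentially no change. The value expected for compound 4 is 128000 nM, most likely reported again as a limit.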

Compound 4, half-maximal inhibitory concentration: > 128000 nM
Compound 4 ended at the assay's limit; the forecaster's own chance of this, stated with the estimate: 85%; the middle value sits exactly at the limit.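

In this assay compound 4 gives > 128000 nM, which is a limit and not a number. No step can be read from compound 3 to compound 4, because both stand at a limit: the limit of > 128000 nM in this assay, at which 4 of the 4 values shown sit.

The compounds shown leave open whether 3-fluoro-4-methoxyphenyl in place of 4-fluorophenyl alters the read-out at all, and at what concentration any of the four compounds would reach half-maximal inhibition in this assay.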